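This account rests on a few compounds, and the source may have more. Where it says the series, first, only, none or still open, it means among the compounds named here.

Series notes, binding in an assay on isolated protein for binding affinity to melatonin receptor type 1A (Homo sapiens); on this read-out higher numbers stand for weaker inhibition and lower numbers for stronger inhibition:

- compound 1 `CCCC(=O)Nc1ccc(Oc2cccc(OC)c2)cc1`: 63 nM
- compound 2 `COc1cccc(Oc2ccc(NC(C)=O)cc2)c1`: 84 nM
- compound 3 `COc1cccc(Oc2ccc(NC(=O)C3CC3)cc2)c1`: 99 nM

Compound 2 stands second highest of the three numbers; its nearest neighbour is compound 3 and its furthest is compound 1, and both gaps sit within the scatter, so on this assay the three measured compounds cannot be told apart.

The next compound, compound 4 `COCC(=O)Nc1ccc(Oc2cccc(OC)c2)cc1`, differs from compound 2 by methoxy in place of hydrogen on a saturated chain carbon bound to a carbonyl carbon. Going by the values given here, the steps that bear on it are those at the same place or at the carbonyl carbon: a 1.3-fold higher number from compound 1 to compound 2 (0.12 log units; within the scatter), a 1.2-fold higher number from compound 2 to compound 3 (0.07 log units; within the scatter) and a 1.6-fold higher number from compound 1 to compound 3 (0.20 log units; within the scatter). All three are within the scatter, so the acyl end has so far accepted methyl, propyl and cyclopropyl without a clear shift. None of them, however, brought in an oxygen on that chain carbon, so compound 4 goes a little beyond what is covered. The expectation for compound 4 is therefore no step beyond the scatter in this assay, written as a 1.4-fold higher number from compound 2 to compound 4 (0.15 log units; within the scatter). The estimate for compound 4 is 120 nM, within 45 nM to 320 nM.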

Compound 4, inhibition constant: 180 nM
The estimate for compound 4 lay 1.5-fold (0.18 log units) below the measured number; the measured number falls inside the stated range.
By their numbers in this assay, from the lowest: compounds 1, 2, 3 and 4 (each within the scatter of the next, the first and the last beyond it).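

In this assay, going by these compounds alone, methoxy in place of hydrogen on the saturated chain carbon bound to a carbonyl carbon gives a 2.1-fold higher number from compound 2 to compound 4 (0.33 log units; beyond the scatter) and is the first change at the acyl end to pass the scatter, though only modestly. Methoxy in place of ethyl at that carbon gives a 2.9-fold higher number from compound 1 to compound 4 (0.46 log units; beyond the scatter) and is also modest, while methoxymethyl in place of cyclopropyl on the carbonyl carbon gives a 1.8-fold higher number from compound 3 to compound 4 (0.26 log units; within the scatter) and leaves compound 3 and compound 4 not separable, so the loss shows against two of the three acyl groups only. Nothing available explains this shift.

From the compounds shown here alone, whether the shift belongs to the oxygen itself or to the methoxy group as a whole remains open. A hydroxy group, an ethoxy group or an amine on that chain carbon would bear on this.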